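The source may hold more compounds than are shown below. What is called first, only, known or untested is meant among the compounds shown, and "the series" means these compounds.

In an ADME assay on Vero cells (Chlorocebus sabaeus) for cytotoxicity, read by neutral red uptake, tested at 197 ug/mL (a lower number here means a stronger effect, a higher number a weaker effect of the compound at the concentration tested), compound 1 `O=C1CSC(c2ccc(F)cc2)N1CCN1CCCCC1` gives 73%, compound 2 `O=C1CSC(c2ccccc2Cl)N1CCN1CCCCC1` gives 71%, and compound 3 `O=C1CSC(c2c(Cl)cccc2Cl)N1CCN1CCCCC1` gives 75%. Compound 2 thus holds the lowest of the three numbers, yet neither other compound lies beyond the scatter of it: the step of a number 2 percentage points lower from compound 1 to compound 2 (within the scatter) and the step of a number 4 percentage points higher from compound 2 to compound 3 (within the scatter) are both small. Compound 4 `O=C1CSC(c2cccc(O)c2)N1CCN1CCCCC1` differs from compound 2 by 3-hydroxyphenyl in place of 2-chlorophenyl on a saturated ring carbon. The step from compound 1 to compound 2 bears most directly on this change, as it also exchanges one aryl group for another on a saturated ring carbon, and it stayed within the scatter, as did the step on to compound 3. Compound 4 is therefore expected to show no step beyond the scatter, a number 1 percentage points higher from compound 2 to compound 4 (within the scatter). Compound 4 is estimated at 72%, within 60% to 84%.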

Compound 4, a percentage reported as activity, at one concentration (the size of the read-out at that concentration, not a potency): 100%
Beside the measured number, compound 4's estimate is 28 percentage points below it; the whole stated range lies below it.
By their numbers in this assay, from the lowest: compounds 2, 1 and 3 (each within the scatter of the next); then compound 4.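

In this assay, the aryl group on this saturated ring carbon can move the number beyond the scatter, which the earlier aryl exchanges did not show: 3-hydroxyphenyl gives a number 29 percentage points higher from compound 2 to compound 4 (beyond the scatter) and a number 27 percentage points higher from compound 1 to compound 4 (beyond the scatter) in the same place. Compared with 2-chlorophenyl, 3-hydroxyphenyl has the same count of heavy atoms but brings a hydrogen-bond donor and acceptor. Nothing at hand explains the step.

On these data alone, whether 4-hydroxyphenyl, 3-methoxyphenyl or 3-aminophenyl would behave like compound 4 remains open. The compounds shown therefore do not separate the hydroxyl group itself from where it sits on the aromatic ring.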